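Swapping a dichlorophenyl for a sulfamoylphenyl on the core

The source may report more compounds than this note shows. Statements on the series, on what has been measured and on what is new or still open speak of the compounds shown alone.

Of the compounds shown here, three sharing one core have been measured in an assay for binding affinity to dual specificity mitogen-activated protein kinase kinase 4 (Homo sapiens), read by KINOMEscan, tested at 100 nM; a lower number here means a stronger effect, a higher number a weaker effect of the compound at the concentration tested. Compound 1 `CCCS(=O)(=O)Nc1ccc(F)c(C(=O)c2n[nH]c3ncc(-c4ccccc4O)cc23)c1F` carries a 2-hydroxyphenyl on the core and in this assay compound 1 gives 9%. Compound 2 `CCCS(=O)(=O)Nc1ccc(F)c(C(=O)c2n[nH]c3ncc(-c4ccc(Cl)c(Cl)c4)cc23)c1F` carries a 3,4-dichlorophenyl in the same place and in this assay compound 2 gives 45%, the highest of the three numbers. Compound 3 `CCCS(=O)(=O)Nc1ccc(F)c(C(=O)c2n[nH]c3ncc(-c4ccc(S(=O)(=O)NC(C)=O)cc4)cc23)c1F` carries a 4-(acetylsulfamoyl)phenyl and in this assay compound 3 gives 0.35%, the lowest of the three.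

For the measured compounds named here, the one step between neighbours that has been measured is a number 36 percentage points higher from compound 1 to compound 2 (beyond the scatter), which shows that the dichlorophenyl sits well above the hydroxyphenyl in this read-out. Compound 4 `CCCS(=O)(=O)Nc1ccc(F)c(C(=O)c2n[nH]c3ncc(-c4ccc(S(N)(=O)=O)cc4C)cc23)c1F` is not yet measured; it differs from compound 2 by 2-methyl-4-sulfamoylphenyl in place of 3,4-dichlorophenyl on an aromatic carbon. The entering group resembles the sulfamoyl-bearing group of compound 3, whose number was the lowest seen, and the measured step from compound 1 to compound 2 shows that leaving the dichlorophenyl behind can move the number down by a large margin.

A downward step is therefore expected, roughly a number 41 percentage points lower from compound 2 to compound 4 (beyond the scatter). Compound 4 is estimated at 4%, within a range of 0.5% to 20%.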

Compound 4, a percentage reported as activity, at one concentration (the size of the read-out at that concentration, not a potency): 3.1%
For compound 4 the middle estimate is 0.9 percentage points above the measured one; measured number inside the range.
By their numbers in this assay, from the lowest: compounds 3, 4 and 1 (each within the scatter of the next); then compound 2.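

Replacing the 3,4-dichlorophenyl with the 2-methyl-4-sulfamoylphenyl gives a number 41.9 percentage points lower from compound 2 to compound 4 (beyond the scatter) in this assay, so this position now has a second replacement that brings the number down by a large margin. The 2-methyl-4-sulfamoylphenyl and the 2-hydroxyphenyl cannot be told apart, with a number 5.9 percentage points lower from compound 1 to compound 4 (within the scatter), even though they carry different groups on their phenyl rings. Compound 2 therefore stands alone, while compounds 1, 3 and 4 lie within the scatter of one another, which shows that a low number at this position does not require a sulfamoyl group, since compound 1 has none.

Nothing available explains what separates the 3,4-dichlorophenyl from the other three groups in this read-out.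

Going by these compounds, it remains open whether the methyl group of compound 4 contributes anything beside the sulfamoyl group, and how a plain phenyl, a 4-chlorophenyl, or a phenyl carrying a carboxylic acid or an amine would read at this position.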